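From compound 3 to compound 4: an added amino group

The compounds below may be only part of what the source reports. "The series", "measured", "known", "first", "only" and "open" are said of these compounds alone.

In a functional assay on PBMC cells (Homo sapiens) for cytotoxicity (a lower number here means a stronger inhibitor, a higher number a weaker inhibitor), compound 1 (`O=c1ccn([C@@H]2S[C@H](CO)[C@H]2CO)c(=O)[nH]1`) gives 8500 nM as a measured number. Compound 2 (`Nc1ncnc2c1ncn2[C@@H]1S[C@H](CO)[C@H]1CO`) gives > 100000 nM as a limit of the assay and not a number. Compound 3 (`OC[C@H]1[C@H](n2cnc3c(O)ncnc32)S[C@@H]1CO`) likewise gives > 100000 nM as a limit. Compound 3 thus stands at the limit of > 100000 nM in this assay, at which 2 of the 3 values shown sit, and has no number of its own.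

Compound 4 (`Nc1nc(O)c2ncn([C@@H]3S[C@H](CO)[C@H]3CO)c2n1`) differs from compound 3 by a single change (amino in place of hydrogen on an aromatic carbon), amino in place of hydrogen on an aromatic carbon, between two ring nitrogen atoms. Among the measured compounds shown here, the only measured step that bears on it is a step that the two limits leave unreadable from compound 2 to compound 3 and it concerns hydroxy in place of amino on an aromatic carbon, so it offers no size to carry over. No shift beyond the scatter is therefore expected in this assay and the expected step is a number no higher from compound 3 to compound 4 (the limit leaves the size open) with no favoured direction. For compound 4 the estimated value is 100000 nM within an expected range from 20000 nM to 200000 nM and the assay may well report only a limit again.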

Compound 4, half-maximal inhibitory concentration: > 100000 nM
Compound 4: no number, only a limit (the forecaster's own chance of this, stated with the estimate: 75%); the middle value sits exactly at the limit.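

Compound 3 and compound 4 each give only a limit of the assay and not a number, so no step between them can be read in this assay: the limit of > 100000 nM in this assay, at which 3 of the 4 values shown sit.

The compounds shown leave open whether the added amino group shifts the half-maximal inhibitory concentration at all, and in which direction.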